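Swapping an imidazole for a methylthiophene at the aryl ring

The source may report more compounds than this note shows. Statements on the series, on what has been measured and on what is new or still open speak of the compounds shown alone.

Of the compounds shown here, three share a common core and have been tested in an assay on isolated protein for inhibition of ubiquitin carboxyl-terminal hydrolase 7 (Homo sapiens), with stated times of 30 min and 2 h; on this read-out lower numbers stand for stronger inhibition and higher numbers for weaker inhibition. Compound 1 `Cn1nc2c(=O)n(CC3(O)CCN(Cc4ccc(-c5ccco5)cc4Cl)CC3)cnc2c1-c1ccc(CNC(=O)C(F)(F)F)cc1` gives 2060 nM. Compound 3 `Cn1nc2c(=O)n(CC3(O)CCN(Cc4ccc(-c5ccco5)cc4Cl)CC3)cnc2c1-c1ccc(CNS(C)(=O)=O)cc1` gives 65.3 nM. Compound 2 `Cn1nc2c(=O)n(CC3(O)CCN(Cc4ccc(-n5ccnc5)cc4Cl)CC3)cnc2c1-c1ccc(CN)cc1` gives 228 nM, the second highest of the three numbers: compound 3 lies nearest with a lower number, and compound 1 lies furthest with a higher number.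

Within the data shown here, the only measured step that changes one place runs a 32-fold lower number from compound 1 to compound 3 (1.50 log units; beyond the scatter). That step concerns the group on the amine nitrogen and says nothing about the aryl ring at the other end of the molecule.

Compound 4 `Cc1ccc(-c2ccc(CN3CCC(O)(Cn4cnc5c(-c6ccc(CN)cc6)n(C)nc5c4=O)CC3)c(Cl)c2)s1` is not yet measured. It differs from compound 2 in one place: 5-methylthiophen-2-yl in place of 1H-imidazol-1-yl on an aromatic carbon. No measured pair isolates this kind of change, and compound 2 alone carries the imidazolyl group, so the step cannot be read from any shown pair. A modest step in this assay is therefore expected, with the direction uncertain; the estimate for compound 4 is 150 nM, within 50 nM to 500 nM, which corresponds to an expected step of a 1.5-fold lower number from compound 2 to compound 4 (0.18 log units; within the scatter).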

Compound 4, half-maximal inhibitory concentration: 101 nM
Compound 4: the middle estimate sits 1.5-fold (0.17 log units) above what was measured; low and high end bracket the measured number.
By their numbers in this assay, from the lowest: compounds 3 and 4 (each within the scatter of the next); then compound 2; then compound 1.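

Among these compounds, the step of a 2.3-fold lower number from compound 2 to compound 4 (0.35 log units; beyond the scatter) in this assay is the first measured change at this position, para to a large group and meta to a chloro group, and it shows that the choice of group here registers in the read-out. The imidazolyl ring, with 2 hetero atoms and 2 hydrogen-bond acceptors, can give way to 5-methylthiophen-2-yl, with 1 hetero atom and 1 hydrogen-bond acceptor, and the number does not rise, so in this pair the ring nitrogens are not required for inhibition in this assay. No measurement of any other kind is available here to explain the difference between these two compounds.

From the compounds shown here alone, what remains open is which part of the new group carries the step, since the ring and its methyl enter together, and thiophen-2-yl without the methyl or a plain phenyl ring would separate the two. The furan-bearing compounds also differ from compound 2 and compound 4 at the amine nitrogen, so a furan-2-yl ring paired with the free aminomethyl group would be needed to place furan in the same series.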